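The compounds below may be only part of what the source reports. "The series", "measured", "known", "first", "only" and "open" are said of these compounds alone.

In a functional assay on MCF7 cells (Homo sapiens) for inhibition, read by fluorescence, with a stated time of 72 h (a lower number here means a stronger inhibitor of growth, a higher number a weaker inhibitor of growth), compound 1 `CCCCCCn1cnc2c(Nc3cccc(Cl)c3)nc(N[C@H]3CC[C@H](N)CC3)nc21` gives 2700 nM, compound 2 `CCCCn1cnc2c(Nc3cccc(Cl)c3)nc(N[C@H]3CC[C@H](N)CC3)nc21` gives 2000 nM and compound 3 `N[C@H]1CC[C@H](Nc2nc(Nc3cccc(Cl)c3)c3ncn(Cc4ccccc4)c3n2)CC1` gives 3600 nM, so compound 3 stands within the scatter of both others. Compound 4 `CC(C)=CCC/C(C)=C/Cn1cnc2c(Nc3cccc(Cl)c3)nc(N[C@H]3CC[C@H](N)CC3)nc21` departs from compound 3 at one place: 2,6-dimethylhepta-1,5-dien-1-yl in place of phenyl on a saturated chain carbon bound to an aromatic nitrogen. Put another way, benzyl gives way to 3,7-dimethylocta-2,6-dien-1-yl. Within the data shown here, three measured steps concern this same place: a 1.4-fold lower number from compound 1 to compound 2 (0.13 log units; within the scatter), a 1.3-fold higher number from compound 1 to compound 3 (0.12 log units; within the scatter) and a 1.8-fold higher number from compound 2 to compound 3 (0.26 log units; within the scatter). Among the measured compounds shown here, all three stay within the scatter, so no step beyond the scatter is expected in this assay, although no measured compound has a chain with double bonds. The expected change is a 1.3-fold lower number from compound 3 to compound 4 (0.11 log units; within the scatter). Compound 4 is estimated at 2800 nM, within an expected range of 1300 nM to 6000 nM.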

Compound 4, concentration for 50% growth inhibition: 3600 nM
Estimate against measurement, compound 4: 1.3-fold (0.11 log units) below; low and high end bracket the measured number.
By their numbers in this assay, from the lowest: compounds 2, 1, 3 and 4 (each within the scatter of the next).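

In this assay the 3,7-dimethylocta-2,6-dien-1-yl group, the first at this place with double bonds outside aromatic rings and no ring, stays within the scatter of all three earlier compounds: no change at the digits printed from compound 3 to compound 4 (within the scatter) and a 1.8-fold higher number from compound 2 to compound 4 (0.26 log units; within the scatter) and a 1.3-fold higher number from compound 1 to compound 4 (0.12 log units; within the scatter). So, on a saturated chain carbon bound to an aromatic nitrogen, the compounds shown span benzyl and this branched unsaturated chain without a step beyond the scatter. Nothing given here explains this result. On these data alone, whether a chain ending in an amine or a carboxylic acid would also stay within the scatter remains open.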